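The source may hold more compounds than are shown below. What is called first, only, known or untested is meant among the compounds shown, and "the series" means these compounds.

Measured compounds:
compound 1, `N=C(N)N/N=C/c1cccc(C(=N)N)c1`, 36 nM
compound 2, `N=C(N)N/N=C/c1cccc(C(N)=O)c1`, 20000 nM
compound 3, `C/C(=N\N=C(N)N)c1cccc(C(=N)N)c1`, 66 nM

In an assay for inhibition of S-adenosylmethionine decarboxylase proenzyme (Rattus norvegicus) (on this read-out lower numbers stand for stronger inhibition and higher numbers for weaker inhibition), compound 3 stands second highest of the three numbers. Its nearest neighbour is compound 1, whose number is lower by a margin that lies within the scatter of repeated measurements, so no order between the two can be read. Its furthest neighbour is compound 2, with a far higher number, a gap that lies beyond the scatter.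

Compound 4, `CC/C(=N\N=C(N)N)c1cccc(C(=N)N)c1`, differs from compound 3 by methyl in place of hydrogen on a saturated chain carbon bound to a carbon with a double bond to nitrogen. Among the measured compounds shown here, the only recorded step, a 560-fold higher number from compound 1 to compound 2 (2.74 log units; beyond the scatter), concerns the group on the aromatic carbon and so does not bear on this change. What does bear on it is the pair of compound 1 and compound 3, which differ at the carbon with the double bond to nitrogen and whose two values in this assay lie within the scatter of each other. Growing the chain by one more carbon at that position is therefore expected to give no step beyond the scatter, the expected step being a 1.2-fold higher number from compound 3 to compound 4 (0.08 log units; within the scatter). Compound 4 is estimated at 80 nM, with a range from 30 nM to 250 nM.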

Compound 4, half-maximal inhibitory concentration: 88 nM
For compound 4 the middle estimate is 1.1-fold (0.04 log units) below the measured one; measured number inside the range.
By their numbers in this assay, from the lowest: compounds 1, 3 and 4 (each within the scatter of the next, the first and the last beyond it); then compound 2.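

In this assay, the change from methyl to ethyl on the carbon with the double bond to nitrogen leaves the number within the scatter, a 1.3-fold higher number from compound 3 to compound 4 (0.12 log units; within the scatter), so this position accepts a further carbon without anything like the large step seen on the aromatic carbon, a 560-fold higher number from compound 1 to compound 2 (2.74 log units; beyond the scatter). Among the compounds shown here, what the earlier compounds could not show is that the extension, though unreadable as a single step, matters across the whole position: compound 1 at 36 nM and compound 4 at 88 nM lie beyond the scatter of each other, while compound 3 lies within the scatter of both. Nothing available here offers an explanation for this behaviour.

The compounds shown leave open how far this position can be grown, since a propyl or longer chain, a branched isopropyl group, a phenyl ring, or a chain ending in an amine or a carboxylic acid does not appear among them. They also leave open whether the ethyl group would give the same result with the carboxamide of compound 2 on the aromatic carbon.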